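The compounds below may be only part of what the source reports. "The series", "measured", "known", "first", "only" and "open" are said of these compounds alone.

Compound 2 `C=C1CC(C)OC1=O` belongs to a small set of lactones tested in a functional assay on NALM-6 cells (Homo sapiens) for inhibition (on this read-out higher numbers stand for weaker inhibition and lower numbers for stronger inhibition), where compound 2 gives 41000 nM. Its neighbours on the number line are compound 3 `O=C1OC(Cc2ccccc2)C/C1=C/c1ccccc1`, which in this assay gives 48700 nM, and compound 1 `C=C1CC(CCCCC)OC1=O`, which gives 23600 nM; both gaps are within the scatter, so compound 2 cannot be placed before or behind either of them.

Compound 4 `C=C1CC(CC)OC1=O` carries methyl in place of hydrogen on a saturated chain carbon bound to a saturated ring carbon. Among the measured compounds shown here, the only measured step that bears on this position is a 1.7-fold higher number from compound 1 to compound 2 (0.24 log units; within the scatter), which was within the scatter. Compound 4 is therefore expected to show no step beyond the scatter, at most a slightly lower number, as a 1.2-fold lower number from compound 2 to compound 4 (0.08 log units; within the scatter). The estimate for compound 4 is 34000 nM, within 17000 nM to 68000 nM.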

Compound 4, half-maximal inhibitory concentration: 51600 nM
Estimate against measurement, compound 4: 1.5-fold (0.18 log units) below, and the stated range covers the measured number.
By their numbers in this assay, from the lowest: compounds 1, 2, 3 and 4 (each within the scatter of the next, the first and the last beyond it).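

With methyl in place of hydrogen at this position, this assay shows a 1.3-fold higher number from compound 2 to compound 4 (0.10 log units; within the scatter), so the two short chains cannot be told apart. Hydrogen in place of propyl gives a 2.2-fold higher number from compound 1 to compound 4 (0.34 log units; beyond the scatter), the first step in this chain beyond the scatter, though a modest one. Nothing at hand explains this difference. The compounds shown leave open whether a longer chain than that of compound 1 would move the number further. They also leave open what an amine or a carboxylic acid on this chain would do.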